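The source may report more compounds than this note shows. Statements on the series, on what has been measured and on what is new or still open speak of the compounds shown alone.

Measured so far in a functional assay on the whole organism with Rattus norvegicus as the target, at a dose of 100 mg/kg; on this read-out higher numbers stand for more inhibition at the one dose given (going by the name of the read-out) and lower numbers for less inhibition:
- compound 1 `CC(C)(C)/N=C(\S)NCCCCn1nc(-c2ccccc2)ccc1=O`: 33.6%
- compound 2 `N/C(S)=N/CCCCn1nc(-c2ccccc2)ccc1=O`: 72%
- compound 3 `N#CNC(=N)NCCCCCCn1nc(-c2ccccc2)ccc1=O`: not yet measured

Compound 2 stands highest of the two numbers in this assay; its nearest neighbour is compound 1, and the step of a number 38.4 percentage points higher from compound 1 to compound 2 (beyond the scatter) lies beyond the scatter. Among the compounds with values here, that one step is the only measured change, and it sits on the same saturated chain carbon as the change now in question.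

Compound 3 differs from compound 2 as follows: a group of 8 heavy atoms (4 carbon, 4 nitrogen; no ring) in place of a group of 4 heavy atoms (1 carbon, 2 nitrogen, 1 sulfur; no ring), on a saturated chain carbon, four bonds along the chain from an aromatic nitrogen. The measured step ran from a larger group to a smaller one on this carbon and gave a large rise; the step to compound 3 runs back to a larger group, though of different make-up, so a fall in this assay is expected, not a rise. The expected step is a number 22 percentage points lower from compound 2 to compound 3 (beyond the scatter), smaller than the measured one. Compound 3 is estimated at 50%, with a range of 25% to 75%.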

Compound 3, a percentage reported as inhibition, in the whole organism at one dose (the size of the read-out at that dose, not a potency): 20.5%
Beside the measured number, compound 3's estimate is 29.5 percentage points above it; measured number below the stated range.
By their numbers in this assay, from the lowest: compound 3; then compound 1; then compound 2.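

In this assay, the step to the larger group, a number 51.5 percentage points lower from compound 2 to compound 3 (beyond the scatter), leaves the group of 4 heavy atoms highest of the three at this saturated chain carbon. Size alone does not settle the order, since the two groups of 8 heavy atoms do not match: the step between them is a number 13.1 percentage points lower from compound 1 to compound 3 (beyond the scatter), so make-up at this place goes with a change in the number at equal heavy-atom count. No evidence is available on why these numbers differ.

On these data alone, whether the end group or the chain carries the change in compound 3 stays open, as both differ from compound 2. A simple primary amine or a carboxylic acid at this place would show whether anything other than the small sulfur-containing group of compound 2 can hold the number up.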